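A few compounds are considered here, and "the series" means these few. Any claim that something is new, unique, unknown or untested is made for them only; others in the source may bear on it.

Measured so far in a functional assay on MCF7 cells (Homo sapiens) for antiproliferative activity, read by MTT assay; a lower number here means a stronger inhibitor, a higher number a weaker inhibitor: compound 1 `CCCCC/C=C\C/C=C\CCCCCCCC1(O)CC(=O)c2c(O)cc(OCOC)cc2O1`, compound 2 `CCCCC/C=C\C/C=C\CCCCCCCc1cc(=O)c2c(O)c(C)c(O)cc2o1`, compound 3 `CCCCCCCCCCCCCCCc1cc(=O)c2c(O)c(C)c(O)cc2o1`.

In this assay compound 1 gives only the limit, > 84100 nM. Compound 2 likewise gives only the limit, > 84100 nM. Compound 3 gives 43200 nM. The step of an at least 1.9-fold lower number from compound 2 to compound 3 (0.28 log units; that floor lies within the scatter) is octyl in place of deca-1,4-dien-1-yl on a saturated chain carbon, seven bonds along the chain from an aromatic carbon; it can be read only as a floor because of the limit of > 84100 nM in this assay, at which 2 of the 3 values shown sit. The difference between the cores of compound 1 and compound 2 is not broken down here. Compound 4 `CCCCCCCCCCCCCCCC1(O)CC(=O)c2c(O)cc(OCOC)cc2O1` is not yet measured and carries the same kind of change, (octyl in place of deca-1,4-dien-1-yl on a saturated chain carbon, seven bonds along the chain from a saturated ring carbon), the place being seven bonds along the chain from a saturated ring carbon rather than from an aromatic carbon. Compound 4 is expected to move by an at least 1.0-fold lower number from compound 1 to compound 4 (0.02 log units; that floor lies within the scatter), an expectation resting on the step of an at least 1.9-fold lower number from compound 2 to compound 3 (0.28 log units; that floor lies within the scatter) lying within the scatter. The estimate for compound 4 is 80000 nM, between 30000 nM and 200000 nM.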

Compound 4, half-maximal inhibitory concentration: > 67200 nM
Compound 4 was reported as a limit; the forecaster's own chance of this, stated with the estimate: 60%; the middle value does not contradict the limit.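

Within the data shown here, compound 1 and compound 4 are both reported only as limits in this assay; no step between them can be read. Going by these compounds, whether octyl in place of deca-1,4-dien-1-yl matters on the core of compound 1 remains open.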